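The source may report more compounds than this note shows. Statements on the series, on what has been measured and on what is new or still open speak of the compounds shown alone.

Measured so far:
- compound 1 `Cc1ccc(NC(=O)N[C@H](C)c2ccccc2)cc1`: in an ADME assay on the whole organism with Oryza sativa as the target, tested at 10 uM (a lower number here means a stronger effect, a higher number a weaker effect of the compound at the concentration tested), compound 1 gives 64%
- compound 2 `CCc1ccc(NC(=O)N[C@H](C)c2ccccc2)cc1`: in this assay compound 2 gives 44%
- compound 3 `CCc1ccc(NC(=O)N[C@@H](C)c2ccccc2)cc1`: in this assay compound 3 gives 91%

Compound 2 stands lowest of the three numbers in this assay; the nearest is compound 1, the furthest compound 3. Two steps have been measured. The first, a number 20 percentage points lower from compound 1 to compound 2 (beyond the scatter), is a chain extension. The second, a number 47 percentage points higher from compound 2 to compound 3 (beyond the scatter), rests only on the fact that compounds 2 and 3 differ only in the configuration as drawn and says nothing about chain length.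

Compound 4 `CCCc1ccc(NC(=O)N[C@H](C)c2ccccc2)cc1` is not yet measured. It differs from compound 2 by methyl in place of hydrogen on a saturated chain carbon, two bonds along the chain from an aromatic carbon. Of the measured steps only a number 20 percentage points lower from compound 1 to compound 2 (beyond the scatter) bears on this change, as it is the same kind of extension cut one bond further in; the stereo step does not. A further lowering in this assay is therefore expected, of modest size or within the scatter, not a large one, since the stereo step is of a different kind. The expected step is a number 9 percentage points lower from compound 2 to compound 4 (within the scatter). Compound 4 is expected to give 35% in this assay, with a range from 15% to 60%.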

Compound 4, a percentage reported as activity, at one concentration (the size of the read-out at that concentration, not a potency): 35%
Compound 4: middle estimate and measured number agree at the digits printed; the measured number falls inside the stated range.
By their numbers in this assay, from the lowest: compounds 4 and 2 (each within the scatter of the next); then compound 1; then compound 3.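

Extending ethyl to propyl at this position, on the saturated chain carbon two bonds along the chain from an aromatic carbon, gives a number 9 percentage points lower from compound 2 to compound 4 (within the scatter) in this assay, so compounds 2 and 4 cannot be told apart here, whereas the extension one bond further in gave a number 20 percentage points lower from compound 1 to compound 2 (beyond the scatter). Going from methyl to propyl in one place still gives a number 29 percentage points lower from compound 1 to compound 4 (beyond the scatter), so the chain length effect over compounds 1, 2 and 4 is carried by the ethyl group, with no separate gain from the added methyl at the chain end. Nothing available explains this difference between the two extensions.

Going by these compounds, it stays open how a longer chain such as butyl, or a propyl chain ending in an amine or a carboxylic acid, reads at this position. On these data alone, it also stays open whether the configuration as drawn counts as much with propyl as with ethyl, where the change gave a number 47 percentage points higher from compound 2 to compound 3 (beyond the scatter).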